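This account rests on a few compounds, and the source may have more. Where it says the series, first, only, none or still open, it means among the compounds named here.

Only one of the three measured compounds here carries a number. In a physicochemical assay for solubility (on this read-out higher numbers stand for higher solubility and lower numbers for lower solubility), compound 1 `CS(=O)(=O)c1ccc(-n2nc(C(F)F)c(C#N)c2-c2ccccc2)cc1` stands as "not determined" (no result reported), and compound 2 `CC1CCCN(c2cc(C(F)(F)F)nn2-c2ccc(S(C)(=O)=O)cn2)C1` stands as "not determined" (no result reported). Among the measured compounds shown here, compound 3 `CC1CCCN(c2c(C#N)c(C(F)(F)F)nn2-c2ccc(S(C)(=O)=O)cn2)C1` reads 100 ug/mL, which makes it the sole reference point, with no other measured compound to rank it against.

The next compound, compound 4 `CC(C)(C)CNc1c(C#N)c(C(F)(F)F)nn1-c1ccc(S(C)(=O)=O)cn1`, keeps the rest of compound 3 and changes one group: neopentylamino in place of 3-methylpiperidin-1-yl on an aromatic carbon. A group built on a six-membered non-aromatic ring gives way to one with no ring.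

For the measured compounds named here, no measured pair in this set shows what such a swap does, so any forecast remains loose. The expectation rests only on compound 3 at 100 ug/mL and on the structural change itself. A modest fall in this assay is expected, near the edge of the usual scatter of repeat measurements, and a result with no real change would be no surprise. The estimated size of the move is a 2.0-fold lower number from compound 3 to compound 4 (0.30 log units; within the scatter). For compound 4 the expected value is 50 ug/mL, with an estimated range from 15 ug/mL to 130 ug/mL.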

Compound 4, solubility: < 25 ug/mL
Compound 4 was reported as a limit; the forecaster's own chance of this, stated with the estimate: 15%; at least 2.0-fold (0.30 log units) between middle value and limit.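

In this assay compound 4 gives < 25 ug/mL and that is a limit of the assay, not a number. Among the compounds shown here, putting neopentylamino in place of 3-methylpiperidin-1-yl on this aromatic carbon is the only step that can be read here, and it gives an at least 4.0-fold lower number from compound 3 to compound 4 (0.60 log units; beyond the scatter), so what this position carries clearly matters to the read-out, which a single value could not show. Going by these compounds, the size printed for that step is only its smallest possible size, and the true gap stays unknown since the reading sits at the end of what this assay reports: the limit of < 25 ug/mL in this assay, at which 1 of the 4 values shown sits.

This one step removes a six-membered non-aromatic ring and also adds a hydrogen-bond donor, so it cannot separate the loss of the ring from the gain of the donor. A morpholine ring at the same position would keep a ring and add no donor, while a dimethylamino group would have no ring and no donor, and the compounds shown do not tell where either would stand.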